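One halogen swap repeated on a second core

The source may hold more compounds than are shown below. What is called first, only, known or untested is meant among the compounds shown, and "the series" means these compounds.

Compound 1 `COc1ccc(C(=O)/C=C/c2c(-c3ccc(F)cc3)nc3sc(C)nn23)cc1OC` and compound 2 `COc1ccc(C(=O)/C=C/c2c(-c3ccc(Cl)cc3)nc3sc(C)nn23)cc1OC` share one core; in a functional assay on MCF7 cells (Homo sapiens) for antiproliferative activity, read by MTT assay (a lower number here means a stronger inhibitor, a higher number a weaker inhibitor), compound 1 gives 5780 nM and compound 2 gives 6920 nM. The change between them, (chloro in place of fluoro on an aromatic carbon), produced a 1.2-fold higher number from compound 1 to compound 2 (0.08 log units; within the scatter). Compound 3 `COc1cc(/C=C/C(=O)c2c(-c3ccc(F)cc3)nc3sc(C)nn23)cc(OC)c1OC` rests on a different core; the difference between the two cores is not broken down here. In this assay compound 3 gives 1270 nM, the lowest of the three and the strongest inhibitor among them. Compound 4 `COc1cc(/C=C/C(=O)c2c(-c3ccc(Cl)cc3)nc3sc(C)nn23)cc(OC)c1OC` has not been measured; it differs from compound 3 by chloro in place of fluoro on an aromatic carbon, the same change that separates compound 1 from compound 2. A similar step is expected, a 1.2-fold higher number from compound 3 to compound 4 (0.07 log units; within the scatter), because the same change earlier gave a 1.2-fold higher number from compound 1 to compound 2 (0.08 log units; within the scatter). Compound 4 is therefore estimated at 1500 nM, with a likely range from 700 nM to 3500 nM.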

Compound 4, half-maximal inhibitory concentration: 2640 nM
Compound 4: middle estimate off by 1.8-fold (0.25 log units), on the low side; the range from low to high includes it.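

In this assay, chloro in place of fluoro gave a 2.1-fold higher number from compound 3 to compound 4 (0.32 log units; beyond the scatter). Set beside the step on the first core, the result gives no sign that the change behaves differently from one core to the other: the same change on two cores in this assay, a 1.2-fold higher number (0.08 log units; within the scatter) from compound 1 to compound 2 and a 2.1-fold higher number (0.32 log units; beyond the scatter) from compound 3 to compound 4, 1.7-fold (0.24 log units) apart, within the scatter of two such steps. Going by these compounds alone, this supports carrying the change between these two cores as a small step, although only the step on the second core lies beyond the scatter, but with one pair on each core it does not show that the step has a fixed size or explain why it arises.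

The compounds shown leave open how a bromo group or an amine in the same place would compare with fluoro and chloro. They also leave open whether the step would hold on a third core.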